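Replacing the cyclobutyl group of compound 3

This account rests on a few compounds, and the source may have more. Where it says the series, first, only, none or still open, it means among the compounds named here.

- compound 1 `CCOC(=O)c1cc(-c2ccc(Cl)cc2)n(-c2ccc3cc[nH]c3c2)c1C`: 5100 nM
- compound 2 `CCOC(=O)c1cc(-c2ccc(F)cc2)n(-c2ccc(S(N)(=O)=O)cc2)c1N`: 7500 nM
- compound 3 `NS(=O)(=O)c1ccc(-c2cc(C(=O)C3CCC3)nn2-c2ccc(Cl)cc2)cc1`: 17200 nM

In a physicochemical assay for solubility, read by HPLC, in phosphate buffer, measured as kinetic solubility, at pH 7.4 (on this read-out higher numbers stand for higher solubility and lower numbers for lower solubility), compound 3 gives 17200 nM, the highest of the three numbers. Its distance to each of the other two lies beyond the usual scatter of repeat measurements, so this gap is more than noise.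

The next molecule is compound 4 `CN(C(=O)c1cc(-c2ccc(S(N)(=O)=O)cc2)n(-c2ccc(Cl)cc2)n1)C1CC(F)(F)C1`, which has not been measured yet. It carries (3,3-difluorocyclobutyl)(methyl)amino in place of cyclobutyl on a carbonyl carbon. In other words, cyclobutylcarbonyl gives way to (3,3-difluorocyclobutyl)(methyl)carbamoyl.

Going by the values given here, no two measured compounds differ in one place only, so the data offer no direct guide to the effect of this change. Any forecast must therefore be rough. Compound 3 sits at the top of a very small set, while compound 2 at 7500 nM and compound 1 at 5100 nM both lie lower. A fall towards those two numbers therefore seems more likely than a further rise. The estimated change in this assay is a 2.2-fold lower number from compound 3 to compound 4 (0.33 log units; beyond the scatter), a modest expected drop with wide uncertainty. For compound 4 the expected value is 8000 nM, within an estimated range of 2500 nM to 20000 nM.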

Compound 4, solubility: 30900 nM
Compound 4: middle estimate off by 3.9-fold (0.59 log units), on the low side; the measured number lies above the stated range.
By their numbers in this assay, from the lowest: compounds 1 and 2 (each within the scatter of the next); then compounds 3 and 4 (each within the scatter of the next).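

In this assay, putting (3,3-difluorocyclobutyl)(methyl)amino in place of cyclobutyl on a carbonyl carbon gives a 1.8-fold higher number from compound 3 to compound 4 (0.25 log units; within the scatter). Going by these compounds alone, this is the first pair in the set that differs in one place only, so it gives the first direct reading of a change at this position: a group of 8 heavy atoms, including nitrogen and fluorine, replaces one of 4 carbon atoms, and the two numbers cannot be told apart from the scatter of repeat measurements. Nothing in the data explains why this swap leaves the read-out within that scatter.

The nitrogen, the methyl and the two fluorines all enter together, so the compounds shown cannot assign any effect to one of these parts alone, and a single pair says nothing about whether other groups at this position would behave the same way. A plain cyclobutylamino group, a ring amine such as morpholine, or a hydroxyl group in the same place on the carbonyl carbon, forming a carboxylic acid, remains an open case.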